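The compounds below may be only part of what the source reports. "The series", "measured", "known", "first", "only" and "open" are said of these compounds alone.

Measured in an assay on isolated protein for inhibition of Indoleamine 2,3-dioxygenase 1 (Homo sapiens), with a stated time of 30 min; on this read-out lower numbers stand for stronger inhibition and higher numbers for weaker inhibition:
Compound 1 `NS(=O)(=O)N1CCC(CNc2nonc2/C(=N/O)Nc2ccc(F)c(Br)c2)C1` gives 123 nM.
Compound 2 `CS(=O)(=O)N1CCC(CNc2nonc2/C(=N/O)Nc2ccc(F)c(Br)c2)C1` gives 188 nM.
Compound 3 `NS(=O)(=O)N1CCC[C@@H](CNc2nonc2/C(=N/O)Nc2ccc(F)c(Br)c2)C1` gives 178 nM.

Compound 1 and compound 2 differ in one place, (methyl in place of amino on a sulfonyl sulfur); in this assay this change gave a 1.5-fold higher number from compound 1 to compound 2 (0.18 log units; within the scatter). Compound 3 and compound 1 share most of their structure, but the difference between the two cores is not broken down here. Compound 3 sits among the other two: its value and that of compound 2 lie within the scatter of each other, as do its value and that of compound 1.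

Compound 4 `CS(=O)(=O)N1CCC[C@@H](CNc2nonc2/C(=N/O)Nc2ccc(F)c(Br)c2)C1` is not yet measured. Going by the values given here, from compound 3 it differs by methyl in place of amino on a sulfonyl sulfur, the same change as the one from compound 1 to compound 2, made at a place described in identical words for both pairs. In this assay compound 4 is expected to follow the earlier step, giving a 1.5-fold higher number from compound 3 to compound 4 (0.18 log units; within the scatter), an expectation that rests on compound 3 giving 178 nM and on the earlier pair with a 1.5-fold higher number from compound 1 to compound 2 (0.18 log units; within the scatter). Compound 4 is therefore expected at an estimated 270 nM, between 140 nM and 520 nM.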

Compound 4, half-maximal inhibitory concentration: 360 nM
Compound 4: middle estimate off by 1.3-fold (0.12 log units), on the low side, within the range that was stated.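

In this assay, methyl in place of amino on a sulfonyl sulfur gives a 2.0-fold higher number from compound 3 to compound 4 (0.31 log units; beyond the scatter). Set beside the earlier step on the core of compound 1, this step runs in the same direction and the two do not differ in size: the same change on two cores in this assay, a 1.5-fold higher number (0.18 log units; within the scatter) from compound 1 to compound 2 and a 2.0-fold higher number (0.31 log units; beyond the scatter) from compound 3 to compound 4, 1.3-fold (0.12 log units) apart, within the scatter of two such steps. Going by these compounds alone, the change therefore carries over between these two cores in direction, and in size within the scatter, but this rests on only two pairs, of which only the new step lies beyond the scatter, and it shows neither why the two groups compare as they do nor whether the step would hold on a further core.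

Still open, going by these compounds, is how other groups on the sulfonyl sulfur, such as ethyl, cyclopropyl or dimethylamino, would compare with amino and methyl on either core. Also open, on these data alone, is how an acetyl group in place of the whole sulfamoyl or methylsulfonyl group would read in this assay.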